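From Chloro to Nitro on the Aryl Ring

The source may report more compounds than this note shows. Statements on the series, on what has been measured and on what is new or still open speak of the compounds shown alone.

Compound 1, `Cc1ccc(C(=O)CCc2nnc(-c3ccccc3)o2)c(C)c1`: 36%
Compound 2, `Cc1ccc(C(=O)CCc2nnc(-c3ccc(Cl)cc3)o2)c(C)c1`: 53.3%

For the measured compounds named here, in a functional assay on the whole organism (strain Wistar) for inhibition, with Rattus norvegicus as the target, with stated times of 30 min and 2 h, at a dose of 20 mg/kg by the oral route (on this read-out lower numbers stand for less inhibition and higher numbers for more inhibition at the one dose given (going by the name of the read-out)), compound 2 stands highest of the two numbers measured so far. Going by the values given here, the only step known, a number 17.3 percentage points higher from compound 1 to compound 2 (beyond the scatter), came with chloro in place of hydrogen on an aromatic carbon. Compound 3, `Cc1ccc(C(=O)CCc2nnc(-c3ccc([N+](=O)[O-])cc3)o2)c(C)c1`, differs from compound 2 by nitro in place of chloro on an aromatic carbon. Among the compounds with values here, no measured step swaps one substituent for another at that place, so the single step bearing on it shows only that a group there raised inhibition. The expected step is therefore small, a number 1.7 percentage points higher from compound 2 to compound 3 (within the scatter), within the scatter. Compound 3 is estimated at 55%, in the range 35% to 75%.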

Compound 3, a percentage reported as inhibition, in the whole organism at one dose (the size of the read-out at that dose, not a potency): 40%
Compound 3: the middle estimate sits 15 percentage points above what was measured; the measured number falls inside the stated range.
By their numbers in this assay, from the lowest: compounds 1 and 3 (each within the scatter of the next); then compound 2.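

The gain at this place belongs to chloro and does not extend to every group put there: in this assay, nitro in place of chloro gave a number 13.3 percentage points lower from compound 2 to compound 3 (beyond the scatter) and removed the advantage. Nitro in place of hydrogen gave a number 4 percentage points higher from compound 1 to compound 3 (within the scatter), so among these compounds only chloro stands clear of the unsubstituted compound 1. Nothing given here accounts for the difference between chloro and nitro.

The compounds shown leave open whether fluoro, methoxy or an amine at this place would match chloro. They also leave open whether chloro would keep its gain elsewhere on the ring.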